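Hydrazone series on a shared core: dimethylamino removal

The source may hold more compounds than are shown below. What is called first, only, known or untested is meant among the compounds shown, and "the series" means these compounds.

Measured compounds:
- compound 1 `CCCSc1nc(N/N=C/c2ccc(N(C)C)cc2)c2nnn(Cc3ccccc3)c2n1`: 13100 nM
- compound 2 `C#CCSc1nc(N/N=C(\C)c2ccccc2O)c2nnn(Cc3ccccc3)c2n1`: 3820 nM

In a functional assay on MGC-803 cells (Homo sapiens) for antiproliferative activity, read by MTT assay, with a stated time of 72 h (on this read-out lower numbers stand for stronger inhibition and higher numbers for weaker inhibition), compound 1 gives 13100 nM, the highest of the two numbers shown; compound 2 gives 3820 nM, a lower number, beyond the scatter. Compound 3 `CCCSc1nc(N/N=C/c2ccccc2)c2nnn(Cc3ccccc3)c2n1` is not yet measured. It differs from compound 1 in one place: hydrogen in place of dimethylamino on an aromatic carbon. Among the measured compounds shown here, no step of this kind is known among the measured compounds, so its size cannot be anchored. The expected change is a 1.1-fold higher number from compound 1 to compound 3 (0.06 log units; within the scatter), a step within the scatter in either direction. Compound 3 is therefore estimated at 15000 nM, between 5000 nM and 45000 nM.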

Compound 3, half-maximal inhibitory concentration: > 64000 nM
Compound 3 was reported as a limit; the forecaster's own chance of this, stated with the estimate: 15%; at least 4.2-fold (0.63 log units) between middle value and limit.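

In this assay, compound 3 gives > 64000 nM, a limit of the assay and not a number. The position on the aromatic carbon para to a large group is therefore not indifferent to this change: hydrogen in place of dimethylamino gives an at least 4.8-fold higher number from compound 1 to compound 3 (0.68 log units; beyond the scatter). The step has only a lower bound, so its full size stays unread: the limit of > 64000 nM in this assay, at which 1 of the 3 values shown sits.

Whether dimethylamino is specifically required stays open, as the compounds shown do not cover a methoxy group, a primary amine or a carboxylic acid at this position. Compound 2 differs from compound 1 and compound 3 in more than one place, so it does not test this change on another side chain.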